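Turning one stereocentre: from compound 3 to compound 4

The source may report more compounds than this note shows. Statements on the series, on what has been measured and on what is new or still open speak of the compounds shown alone.

Three measured compounds share a core in which a thiophene-bearing acid is linked through a benzyloxy bridge to a dimethylphenyl group. Compound 1 `COC(CC(=O)O)c1ccc(OCc2cccc(-c3c(C)cccc3C)c2)s1` carries a methoxy group on the chain carbon and gives 210 nM in a functional assay on cells for agonist activity at Free fatty acid receptor 1 (Homo sapiens), read by calcium flux; a lower number here means that less compound is needed, a higher number that more compound is needed for the effect. Compound 2 `Cc1cccc(C)c1-c1cccc(OCc2ccc(CCC(=O)O)s2)c1`, whose chain carries no substituent, gives 2420 nM. Compound 3 `CC#C[C@@H](CC(=O)O)c1ccc(OCc2cccc(-c3c(C)cc(OCCCS(C)(=O)=O)cc3C)c2)s1`, with a propynyl group on the chain carbon and a methylsulfonylpropoxy group on the outer ring, gives 81 nM, the lowest of the three numbers; its gap to compound 1 and its gap to compound 2 both lie beyond the usual scatter.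

Compound 4 `CC#C[C@H](CC(=O)O)c1ccc(OCc2cccc(-c3c(C)cc(OCCCS(C)(=O)=O)cc3C)c2)s1` is its mirror partner at the chain carbon: the two compounds have the same atoms and bonds and differ only in configuration as drawn: 1 of 1 stereo elements differ; a stereocentre at a saturated chain carbon is drawn R in compound 3 and S in compound 4. Going by the values given here, no measured pair here shows the effect of such an inversion, so the size of the step is open. Because compound 3 already stands at 81 nM, the expectation is that compound 4 needs more, with a step of a 9.9-fold higher number from compound 3 to compound 4 (0.99 log units; beyond the scatter) anticipated. For compound 4 a value of 800 nM is estimated, within a range from 200 nM to 4000 nM.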

Compound 4, half-maximal effective concentration: 410 nM
For compound 4 the middle estimate is 2.0-fold (0.29 log units) above the measured one; the measured number falls inside the stated range.
By their numbers in this assay, from the lowest: compound 3; then compounds 1 and 4 (each within the scatter of the next); then compound 2.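

In this assay, inverting the chain carbon gives a 5.1-fold higher number from compound 3 to compound 4 (0.70 log units; beyond the scatter), so the spatial arrangement at this position matters in its own right, and the drawn R form needs less compound than the drawn S form. The earlier compounds shown here could not show this, as each pair among them differs in more than one place, whereas this step can be assigned to the chain carbon alone because nothing else separates the pair: the fact that compounds 3 and 4 differ only in the configuration as drawn. The step is modest, and compound 4 still gives a measurable response at 410 nM.

On these data alone, whether inversion has a similar effect with a different group on the chain carbon, such as a cyclopropyl group or an amine, remains open. The numbers also record only how much compound is needed, not how the inversion produces this difference.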